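Aminopyridine nitrile series: cyclobutyl carboxamide in place of cyclohexanol

The source may report more compounds than this note shows. Statements on the series, on what has been measured and on what is new or still open speak of the compounds shown alone.

Values in an assay on isolated protein for inhibition of protein kinase C delta type (Homo sapiens), read by TR-FRET, with a stated time of 2 h; a lower number here means a stronger inhibitor, a higher number a weaker inhibitor:
compound 1, `N#Cc1cnc(NCc2cnccc2C(F)(F)F)cc1NCCC1CCOCC1`: > 10000 nM
compound 2, `CC1(C)C[C@H](Nc2cc(NCc3cnccc3C(F)(F)F)ncc2C#N)CC[C@@H]1O`: 500 nM.

Compound 1 has only a limit in the assay, not a number. Compound 1 sits at the limit of > 10000 nM in this assay, at which 1 of the 2 values shown sits. Among the measured compounds shown here, compound 2 is the only compound with a measured number in this assay, so its standing cannot be ranked further. For the measured compounds named here, the one measured step, an at least 20-fold lower number from compound 1 to compound 2 (1.30 log units; beyond the scatter), shows that the group on the ring nitrogen governs the read-out strongly.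

Compound 3, `CC1(C)[C@@H](Nc2cc(NCc3cnccc3C(F)(F)F)ncc2C#N)C[C@H]1C(N)=O`, is not yet measured. It differs from compound 2 by 3-carbamoyl-2,2-dimethylcyclobutyl in place of 4-hydroxy-3,3-dimethylcyclohexyl on a nitrogen on an aromatic ring. That measured step bears on the same position but exchanged a different pair of groups, so it fixes the sensitivity of the site rather than the direction of this change. A moderate weakening is expected, a 2.4-fold higher number from compound 2 to compound 3 (0.38 log units; beyond the scatter). Compound 3 is therefore estimated at 1200 nM, within 250 nM to 6000 nM.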

Compound 3, half-maximal inhibitory concentration: 4500 nM
Estimate against measurement, compound 3: 3.8-fold (0.57 log units) below; measured number inside the range.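

In this assay the step to 3-carbamoyl-2,2-dimethylcyclobutyl is a clear loss, with a 9.0-fold higher number from compound 2 to compound 3 (0.95 log units; beyond the scatter), so matching the heavy-atom, donor and acceptor counts of 4-hydroxy-3,3-dimethylcyclohexyl does not preserve its level. The new group still improves on 2-(oxan-4-yl)ethyl, with an at least 2.2-fold lower number from compound 1 to compound 3 (0.34 log units; beyond the scatter), so the gain over that chain is not confined to 4-hydroxy-3,3-dimethylcyclohexyl. That step gives a bound rather than a size, since compound 1 carries only a limit: the limit of > 10000 nM in this assay, at which 1 of the 3 values shown sits.

Ring size and the exchange of hydroxy for carbamoyl change together between these two groups, and the compounds shown do not separate them. Going by these compounds, a 3-hydroxy-2,2-dimethylcyclobutyl group on the same nitrogen would separate the two, and the reading of a carboxylic acid in place of the carbamoyl also stays open.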